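Working notes: from compound 2 to compound 4

The source may report more compounds than this note shows. Statements on the series, on what has been measured and on what is new or still open speak of the compounds shown alone.

compound 1 `Cc1ccccc1-n1cc(-c2ccc(/C=C3\C(=O)Nc4ccccc43)cc2)nn1`: 14700 nM
compound 2 `O=C1Nc2ccccc2/C1=C/c1ccc(-c2cn(-c3ccc(F)cc3)nn2)cc1`: 14700 nM
compound 3 `N#Cc1ccccc1-n1cc(-c2ccc(/C=C3\C(=O)Nc4ccccc43)cc2)nn1`: 19700 nM

In an ADME assay on HUVEC cells (Homo sapiens) for inhibition, read by CCK-8 assay, with a stated time of 24 h, in the presence of a further agent that is not named here (on this read-out lower numbers stand for stronger inhibition and higher numbers for weaker inhibition), compound 2 gives 14700 nM and sits level with compound 1 at the digits shown, with compound 3 within the scatter of both. Compound 4 `O=C1Nc2ccccc2/C1=C/c1ccc(-c2cn(-c3ccc(Cl)c(C(F)(F)F)c3)nn2)cc1` is still unmeasured. Its difference from compound 2 is 4-chloro-3-(trifluoromethyl)phenyl in place of 4-fluorophenyl on an aromatic nitrogen with 4-chloro-3-(trifluoromethyl)phenyl in place of 4-fluorophenyl on an aromatic nitrogen. Exchanges at that same place gave no change at the digits printed from compound 1 to compound 2 (within the scatter) and a 1.3-fold higher number from compound 2 to compound 3 (0.13 log units; within the scatter) and both lie within the scatter. Within the data shown here, no measured compound carries chlorine or trifluoromethyl, so this support is indirect. The expected step is a 1.2-fold lower number from compound 2 to compound 4 (0.09 log units; within the scatter) and no change beyond the scatter is expected in this assay for it. The value of compound 4 is estimated at 12000 nM with an expected range from 4500 nM to 28000 nM.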

Compound 4, half-maximal inhibitory concentration: > 20000 nM
Compound 4 ended at the assay's limit; the forecaster's own chance of this, stated with the estimate: 5%; middle value at least 1.6-fold (0.22 log units) from the limit.
By their numbers in this assay, from the lowest: compounds 1, 2 and 3 (each within the scatter of the next). At a limit, above all of these: compound 4.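

In this assay compound 4 gives no number, only a limit of the assay: the limit of > 20000 nM in this assay, at which 1 of the 4 values shown sits. The position on the aromatic nitrogen thus yields, with 4-chloro-3-(trifluoromethyl)phenyl, its first reading that is a limit rather than a value. The floors are an at least 1.3-fold higher number from compound 2 to compound 4 (0.13 log units; that floor lies within the scatter) and an at least 1.3-fold higher number from compound 1 to compound 4 (0.13 log units; that floor lies within the scatter) and an at least 1.0-fold higher number from compound 3 to compound 4 (0.00 log units; that floor lies within the scatter) and so establish no change beyond the scatter.

On these data alone, how far compound 4 lies past the limit stays open. So does whether an amine or a carboxylic acid on this phenyl ring would shift the reading.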